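Methyl to Chloro on the Aryl Amine of Compound 2

The source may report more compounds than this note shows. Statements on the series, on what has been measured and on what is new or still open speak of the compounds shown alone.

In an assay on cell membranes for displacement of a labelled ligand from Neuronal acetylcholine receptor; alpha4/beta2 (Rattus norvegicus) (a higher number here means a weaker inhibitor, a lower number a stronger inhibitor), compound 1 `COc1ccc(Nc2cncc(N3CC4CC(C3)N4)c2)cc1` gives 0.0598 nM.
In this assay, compound 2 `Cc1ccc(Nc2cncc(N3CC4CC(C3)N4)c2)cc1` gives 0.148 nM.
In this assay, compound 3 `O=[N+]([O-])c1ccc(Nc2ccc(N3CC4CC(C3)N4)cn2)cc1` gives 1.76 nM.

Among these three numbers compound 2 stands second highest. Among the compounds with values here, its nearest neighbour is compound 1, which sits below it: the only measured change at one place, a 2.5-fold higher number from compound 1 to compound 2 (0.39 log units; beyond the scatter), shows a modest shift for swapping one small group for another on the outer ring. Within the data shown here, compound 3, with 1.76 nM, sits far above both and shares no single-place step with compound 2, so its value is simply recorded here.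

The next compound, compound 4 `Clc1ccc(Nc2cncc(N3CC4CC(C3)N4)c2)cc1`, is reached from compound 2 by chloro in place of methyl on an aromatic carbon. The step that bears on it is a 2.5-fold higher number from compound 1 to compound 2 (0.39 log units; beyond the scatter), which says that exchanging one small group for another at this spot moves the number modestly. Among the measured compounds shown here, no measured pair shows chloro entering in place of methyl, so the direction of the step is open. The expectation is therefore a step of modest size at most in this assay, close to the scatter, estimated as a 1.0-fold higher number from compound 2 to compound 4 (0.01 log units; within the scatter). Compound 4 is expected to give 0.15 nM, within a range from 0.05 nM to 0.45 nM.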

Compound 4, inhibition constant: 0.118 nM
The estimate for compound 4 lay 1.3-fold (0.10 log units) above the measured number; measured number inside the range.
By their numbers in this assay, from the lowest: compounds 1, 4 and 2 (each within the scatter of the next, the first and the last beyond it); then compound 3.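

In this assay the change from methyl to chloro gives a 1.3-fold lower number from compound 2 to compound 4 (0.10 log units; within the scatter), so among these compounds the two groups cannot be told apart on the outer ring. The new compound also narrows the picture left by the earlier swap of methoxy for methyl, which gave a 2.5-fold higher number from compound 1 to compound 2 (0.39 log units; beyond the scatter) and lay beyond the scatter: replacing methoxy with chloro gives a 2.0-fold higher number from compound 1 to compound 4 (0.30 log units; within the scatter), so of the three pairs with this core only the methoxy and methyl compounds are separated, and only modestly. Nothing measured here explains why these three groups give such similar numbers.

Only methoxy, methyl and chloro are shown at this position, so whether an amine, a carboxylic acid or a longer chain such as butyl would stay in the same narrow band remains open. Compound 3 carries a nitro group but also differs in its core, so it cannot show what nitro alone does here, and the effect of chloro at any other place on the outer ring is also unknown.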